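A few compounds are considered here, and "the series" means these few. Any claim that something is new, unique, unknown or untested is made for them only; others in the source may bear on it.

Compound 3 `CC(C)(C)OC(=O)Nc1ncc(C(Oc2ccc3cc(Br)ccc3c2)c2ccc(Cl)cc2)s1` carries a tert-butoxycarbonyl group on the amino nitrogen of its shared core. In an ADME assay on HepG2 2.2.15 cells (Homo sapiens) for cytotoxicity (a higher number here means that more compound is tolerated, a lower number that less compound is tolerated), compound 3 gives only a limit, > 50000 nM. Its two companions stand at the same point. Compound 1 `Cc1cc(C(C)C)ccc1OC(c1ccc(Cl)cc1)c1cnc(NC(=O)OC(C)(C)C)s1` gives > 50000 nM in this assay, which is a limit rather than a number. Compound 2 `CC(C)(C)OC(=O)Nc1ncc(C(Oc2cccc(C#N)c2)c2ccc(Cl)cc2)s1` likewise gives > 50000 nM, again a limit. As a result the steps a step that the two limits leave unreadable from compound 1 to compound 2, a step that the two limits leave unreadable from compound 1 to compound 3 and a step that the two limits leave unreadable from compound 2 to compound 3 cannot be sized; all that the measurements show is the limit of > 50000 nM in this assay, at which 3 of the 3 values shown sit. Compound 4 `Cc1ccc(C(=O)Nc2ncc(C(Oc3ccc4cc(Br)ccc4c3)c3ccc(Cl)cc3)s2)cc1` differs from compound 3 by 4-methylphenyl in place of tert-butoxy on a carbonyl carbon. For the measured compounds named here, none of the measured steps touches the carbonyl carbon, so they give no reading for this change; they only show that the shared core has tolerated three different ether partners without a number emerging. The expected step is therefore a number no higher from compound 3 to compound 4 (the limit leaves the size open), not beyond the scatter. Compound 4 is estimated at 50000 nM, with a range from 15000 nM to 150000 nM.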

Compound 4, half-maximal cytotoxic concentration: "not toxic" (no number reported)
Compound 4: no number reported, so the estimate cannot be set against anything.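

No new step can be read from compound 3 to compound 4: in this assay compound 4 is reported only as not toxic, without a number, while compound 3 gives only a limit. The compounds shown leave open what size of change, if any, 4-methylphenyl in place of tert-butoxy brings.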